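Aryl hydrazone swap on a shared core, cytotoxicity expected

The source may hold more compounds than are shown below. What is called first, only, known or untested is meant among the compounds shown, and "the series" means these compounds.

The series rests on one shared core carrying an aryl hydrazone at its tip. Going by the values given here, compound 1 `CN(C)CCn1cnnc1-c1cc(Oc2ccc(NC(=O)N/N=C/c3c[nH]c4ccccc34)cc2F)ccn1` is the only member with a number: in an ADME assay on WI-38 cells (Homo sapiens) for cytotoxicity, read by MTT assay, with a stated time of 72 h (on this read-out higher numbers stand for weaker inhibition and lower numbers for stronger inhibition), compound 1 gives 3620 nM. Compound 2 `CN(C)CCn1cnnc1-c1cc(Oc2ccc(NC(=O)N/N=C/c3ccccc3)cc2F)ccn1` carries a plain phenyl at that position, and in this assay compound 2 is recorded as "not determined" (no result reported), so it stands without a number. Compound 3 `CN(C)CCn1cnnc1-c1cc(Oc2ccc(NC(=O)N/N=C/c3cc(Br)c(O)c(Br)c3)cc2F)ccn1` likewise stands in this assay as "not determined" (no result reported), without a number. Compound 4 `Cc1cc(/C=N/NC(=O)Nc2ccc(Oc3ccnc(-c4nncn4CCN(C)C)c3)c(F)c2)cc(C)c1O` differs from compound 2 by 4-hydroxy-3,5-dimethylphenyl in place of phenyl on a carbon with a double bond to nitrogen. Among the compounds with values here, with no measured pair to set a size for this change, and with compound 2 itself unmeasured, the expectation for compound 4 has to lean on the one number in hand, that of compound 1. Nothing in the data points to a direction for the step, so no shift beyond the scatter is expected in this assay. Compound 4 is therefore estimated at 4000 nM in this assay, within a range from 1500 nM to 12000 nM.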

Compound 4, half-maximal inhibitory concentration: 3610 nM
For compound 4 the middle estimate is 1.1-fold (0.04 log units) above the measured one; measured number inside the range.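

In this assay, going by these compounds alone, placing 4-hydroxy-3,5-dimethylphenyl instead of 1H-indol-3-yl on a carbon with a double bond to nitrogen gives a 1.0-fold lower number from compound 1 to compound 4 (0.00 log units; within the scatter), the first step that can be read at this position. The two aryl groups, a fused indole and a substituted phenyl, therefore sit at this place with values that cannot be told apart in this cytotoxicity read-out, so this one exchange gives no sign that the choice of aryl group matters. No available evidence accounts for this result.

Steps involving compound 2 and compound 3 cannot be read, so the plain phenyl and the hydroxy and bromo substitution of compound 3 remain unplaced against compound 1 and compound 4. From the compounds shown here alone, whether an aryl group carrying an amine or a carboxylic acid would keep this level also remains open.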